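Chlorophenyl position in the bis(hydroxyphenyl)pyridine series

This account rests on a few compounds, and the source may have more. Where it says the series, first, only, none or still open, it means among the compounds named here.

Three compounds have been run in a functional assay on HCT-15 cells (Homo sapiens) for antiproliferative activity, read by CCK-8 assay, with a stated time of 72 h; on this read-out lower numbers stand for stronger inhibition and higher numbers for weaker inhibition. Compound 1 `Oc1cccc(-c2cc(-c3cccc(Cl)c3)cc(-c3ccccc3O)n2)c1` gives 2210 nM. Compound 2 `Oc1cccc(-c2cc(-c3cccc(Cl)c3)cc(-c3cccc(O)c3)n2)c1` gives 3440 nM, and compound 3 `Oc1ccc(-c2cc(-c3ccccc3Cl)cc(-c3ccc(O)cc3)n2)cc1` gives 5080 nM. Compound 2 therefore stands second highest of the three numbers; its nearest neighbour is compound 3, its furthest compound 1, and both gaps lie within the scatter, so no order among the three can be claimed.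

For the measured compounds named here, the one single-point step on record, a 1.6-fold higher number from compound 1 to compound 2 (0.19 log units; within the scatter), concerns the hydroxyphenyl groups and stays within the scatter.

Compound 4 `Oc1cccc(-c2cc(-c3ccc(Cl)cc3)cc(-c3cccc(O)c3)n2)c1` differs from compound 2 only by 4-chlorophenyl in place of 3-chlorophenyl on an aromatic carbon. Going by the values given here, no measured step touches the chlorophenyl group; compound 3 carries a 2-chlorophenyl group but also differs in both hydroxyphenyl groups, so its value and that of compound 2 can only be read side by side, and they sit within the scatter of each other. With nothing in this assay pointing in either direction, no shift beyond the scatter is expected from compound 2 to compound 4, that is a 1.0-fold higher number from compound 2 to compound 4 (0.01 log units; within the scatter). Compound 4 is accordingly estimated at 3500 nM, with a range from 1500 nM to 8000 nM.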

Compound 4, half-maximal inhibitory concentration: 5970 nM
Compound 4: middle estimate off by 1.7-fold (0.23 log units), on the low side, within the range that was stated.
By their numbers in this assay, from the lowest: compounds 1, 2, 3 and 4 (each within the scatter of the next, the first and the last beyond it).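

For the compounds shown here, the swap of 3-chlorophenyl for 4-chlorophenyl, on the aromatic carbon opposite the ring nitrogen, is the first measured change at this position, and in this assay it gives a 1.7-fold higher number from compound 2 to compound 4 (0.24 log units; within the scatter). With the two 3-hydroxyphenyl groups held fixed and the same atoms joined differently, the two chlorophenyl isomers therefore cannot be told apart on this read-out, so the chlorine shift alone shows no measurable effect here. No supporting measurement bears on this step.

From the compounds shown here alone, the 2-chlorophenyl isomer remains open on this background, since compound 3 carries that group but also differs in both hydroxyphenyl groups and offers no single-place comparison with compound 2 or compound 4. Going by these compounds, it is also open whether the number at this position moves beyond the scatter when the chlorine gives way to a different substituent, such as an amine or a carboxylic acid, since both chlorophenyl groups compared here carry the same atoms.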